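The source may hold more compounds than are shown below. What is called first, only, known or untested is meant among the compounds shown, and "the series" means these compounds.

In a functional assay on RKOp27 cells (Homo sapiens) for cytotoxicity, read by MTT assay, with a stated time of 3 days (on this read-out higher numbers stand for weaker inhibition and lower numbers for stronger inhibition), compound 1 `N#Cc1c(Cl)nc(SCc2nc3ccccc3[nH]2)nc1-c1ccccc1` gives 4.38 nM, compound 2 `N#Cc1c(NN)nc(SCc2nc3ccccc3[nH]2)nc1-c1ccccc1` gives 2.55 nM and compound 3 `N#Cc1c(NNC(N)=S)nc(SCc2nc3ccccc3[nH]2)nc1-c1ccccc1` gives 3.2 nM. Compound 3 therefore lies within the scatter of both other compounds, and the three cannot be ranked.

Compound 4 `N#Cc1c(NC(N)=S)nc(SCc2nc3ccccc3[nH]2)nc1-c1ccccc1` differs from compound 3 as follows: a group of 3 heavy atoms (1 carbon, 1 nitrogen, 1 sulfur; no ring) in place of a group of 4 heavy atoms (1 carbon, 2 nitrogen, 1 sulfur; no ring), on a nitrogen on an aromatic ring. Among the compounds with values here, no measured step makes this exact replacement, but three steps bear on it, as each alters the one place where the measured compounds differ. Replacing chloro gives a 1.7-fold lower number from compound 1 to compound 2 (0.23 log units; within the scatter). The larger replacement of the chlorine atom gives a 1.4-fold lower number from compound 1 to compound 3 (0.14 log units; within the scatter). Adding a group on the amine nitrogen gives a 1.3-fold higher number from compound 2 to compound 3 (0.10 log units; within the scatter).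

All three steps stay within the scatter, so no step beyond the scatter is expected in this assay, although three compounds are a thin basis. The expected step is a 1.1-fold higher number from compound 3 to compound 4 (0.04 log units; within the scatter). The estimate for compound 4 is 3.5 nM, with an expected range of 1.5 nM to 8 nM.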

Compound 4, half-maximal inhibitory concentration: 2.63 nM
Compound 4: middle estimate off by 1.3-fold (0.12 log units), on the high side; measured number inside the range.
By their numbers in this assay, from the lowest: compounds 2, 4, 3 and 1 (each within the scatter of the next).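

In this assay, removing one nitrogen from the chain, with the group of 3 heavy atoms in place of the group of 4 heavy atoms on a nitrogen on an aromatic ring, gives a 1.2-fold lower number from compound 3 to compound 4 (0.09 log units; within the scatter). The same group in place of one nitrogen atom gives a 1.0-fold higher number from compound 2 to compound 4 (0.01 log units; within the scatter), and the group of 4 heavy atoms in place of one chlorine atom gives a 1.7-fold lower number from compound 1 to compound 4 (0.22 log units; within the scatter), so a fourth substituent at this place on the shared core still produces no step beyond the scatter. Nothing available accounts for these small steps.

Open, from the compounds shown here alone, is whether a carboxylic acid or a longer alkyl chain at this place would give a step beyond the scatter. Also open, going by these compounds, is whether a piperidine ring there would do so.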